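A few compounds are considered here, and "the series" means these few. Any claim that something is new, unique, unknown or untested is made for them only; others in the source may bear on it.

Compound 3, `Cc1nc(S(C)(=O)=O)ccc1Oc1ncnc(OC2CCN(C(=O)OC(C)F)CC2)c1F`, sits at the high end of the three measured numbers in a functional assay on isolated protein for inhibition of Glucose-dependent insulinotropic receptor (Rattus norvegicus), read by HTRF and cAMP accumulation; on this read-out lower numbers stand for an effect already at smaller amounts and higher numbers for an effect only at larger amounts of compound: compound 3 gives 315 nM, whereas compound 1, `Cc1nc(S(C)(=O)=O)ccc1Oc1ncnc(OC2CCN(C(=O)OC(C)C)CC2)c1F`, gives 142 nM and compound 2, `Cc1nc(S(C)(=O)=O)ccc1Oc1ncnc(OC2CCN(C(=O)OC3CCC3)CC2)c1F`, gives 167 nM. The step of a 2.2-fold higher number from compound 1 to compound 3 (0.35 log units; beyond the scatter) is the only one beyond the scatter; a 1.9-fold higher number from compound 2 to compound 3 (0.28 log units; within the scatter) stays within it, as does a 1.2-fold higher number from compound 1 to compound 2 (0.07 log units; within the scatter).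

Compound 4, `Cc1nc(S(C)(=O)=O)ccc1Oc1ncnc(OC2CCN(C(=O)SC3CC3)CC2)c1F`, differs from compound 3 by a group of 4 heavy atoms (3 carbon, 1 sulfur; one three-membered non-aromatic ring of carbon only) in place of a group of 4 heavy atoms (2 carbon, 1 oxygen, 1 fluorine; no ring), on a carbonyl carbon. Going by the values given here, two measured steps bear on this. The methyl-to-fluoro step a 2.2-fold higher number from compound 1 to compound 3 (0.35 log units; beyond the scatter) moved the number up when fluorine came in, and the step of a 1.9-fold higher number from compound 2 to compound 3 (0.28 log units; within the scatter) moved it up when a ring gave way to the 1-fluoroethyl group. Among the compounds with values here, in compound 4 the fluorine leaves and a ring enters, so a movement back toward the numbers of compound 1 and compound 2 is the plausible direction, though the sulfur on the carbonyl carbon has no measured precedent here. Compound 4 is therefore expected to show a 1.6-fold lower number from compound 3 to compound 4 (0.20 log units; within the scatter), with an estimated value of 200 nM in this assay, most likely between 95 nM and 450 nM.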

Compound 4, half-maximal effective concentration: 126 nM
Beside the measured number, compound 4's estimate is 1.6-fold (0.20 log units) above it; measured number inside the range.
By their numbers in this assay, from the lowest: compounds 4, 1, 2 and 3 (each within the scatter of the next, the first and the last beyond it).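

In this assay the step of a 2.5-fold lower number from compound 3 to compound 4 (0.40 log units; beyond the scatter) is the only new one beyond the scatter, whereas a 1.3-fold lower number from compound 2 to compound 4 (0.12 log units; within the scatter) and a 1.1-fold lower number from compound 1 to compound 4 (0.05 log units; within the scatter) both stay within it. A group holding sulfur and a three-membered ring, on a carbonyl carbon whose other neighbour is the amide-type nitrogen in a ring, therefore reads alike with the oxygen-linked groups of compound 1 and compound 2, and only compound 3, with its 1-fluoroethyl group, stands apart from compound 4. Nothing shown here gives a cause for these differences.

The compounds shown do not separate the sulfur from the three-membered ring, as no pair among them changes only one of the two. Also open, on these data alone, is how a longer chain on the sulfur, or an amine on the carbonyl carbon in its place, would read.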